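Swapping the ring-amine substituent in a shared core

A few compounds are considered here, and "the series" means these few. Any claim that something is new, unique, unknown or untested is made for them only; others in the source may bear on it.

Among the compounds with values here, compound 2 `C(#Cc1nc2c(s1)CN(C1CCCCC1)CC2)c1ccccc1` is one of two compounds measured in an assay on HEK293 cells for positive allosteric modulation of metabotropic glutamate receptor 5 (Homo sapiens), read by FLIPR, with a stated time of 1 h; a higher number here means that more compound is needed for the effect, a lower number that less compound is needed. In this assay compound 2 gives only a limit, > 10000 nM. Compound 1 `Fc1cccc(C#Cc2nc3c(s2)CN(C2CCC2)CC3)c1` likewise returns only a limit in this assay, > 10000 nM. Both values sit at the limit of > 10000 nM in this assay, at which 2 of the 2 values shown sit, so compound 2 stands at the limit every value shown shares. Compound 3 `O=S(=O)(C1CC1)N1CCc2nc(C#Cc3ccccc3)sc2C1` differs from compound 2 by cyclopropylsulfonyl in place of cyclohexyl on an amine nitrogen in a ring. No step between measured compounds is shown, and the two limits give no direction. A modest step toward less compound is expected, an at least 2.0-fold lower number from compound 2 to compound 3 (0.30 log units; that floor lies within the scatter), with a real chance of another limit. For compound 3 in this assay an estimate of 5000 nM is given, between 500 nM and 10000 nM.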

Compound 3, half-maximal effective concentration: > 10000 nM
Compound 3 gave a limit, no number; the forecaster's own chance of this, stated with the estimate: 55%; middle value at least 2.0-fold (0.30 log units) from the limit.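

In this assay compound 3 gives > 10000 nM, which is a limit and not a number. Within the data shown here, no step from compound 2 to compound 3 can therefore be read. The compounds shown leave open how far each lies beyond the limit they share: the limit of > 10000 nM in this assay, at which 3 of the 3 values shown sit.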